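1,3-Thiazol-2-yl in Place of 4,6-Dimethylpyrimidin-2-yl

The compounds below may be only part of what the source reports. "The series", "measured", "known", "first", "only" and "open" are said of these compounds alone.

Measured compounds:
compound 1, `Cc1ccc(C(/C=C/c2ccc(F)cc2)=N\Nc2nncc3ccccc23)cc1`, 5.3 nM
compound 2, `O=S(=O)(Nc1ccccn1)c1ccc(Nc2nncc3ccccc23)cc1`, 44 nM
compound 3, `Cc1cc(C)nc(NS(=O)(=O)c2ccc(Nc3nncc4ccccc34)cc2)n1`, 3.4 nM

In a functional assay on UO-31 cells (Homo sapiens) for antiproliferative activity, read by sulforhodamine B assay, with a stated time of 72 h (a lower number here means a stronger inhibitor, a higher number a weaker inhibitor), compound 3 gives the lowest number of the three. Compound 1 lies within the scatter of it, so no order between the two can be claimed, while compound 2 stands clearly apart. Going by the values given here, the single measured step at the sulfonamide nitrogen, a 13-fold lower number from compound 2 to compound 3 (1.11 log units; beyond the scatter), shows that the group on that nitrogen can move the number a great deal.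

Compound 4 is `O=S(=O)(Nc1nccs1)c1ccc(Nc2nncc3ccccc23)cc1`. Its difference from compound 3 is 1,3-thiazol-2-yl in place of 4,6-dimethylpyrimidin-2-yl on a sulfonamide nitrogen. Among the compounds with values here, the only step that bears on this place is the one from compound 2 to compound 3, and it does not involve a five-membered ring, so there is no close precedent. Given that the one known change at this nitrogen was large, compound 4 is expected to drift to a somewhat higher number, by about a 2.6-fold higher number from compound 3 to compound 4 (0.42 log units; beyond the scatter). Compound 4 is therefore estimated at 9 nM, with a range from 3 nM to 30 nM.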

Compound 4, half-maximal inhibitory concentration: 12 nM
Compound 4: middle estimate off by 1.3-fold (0.12 log units), on the low side; measured number inside the range.
By their numbers in this assay, from the lowest: compounds 3 and 1 (each within the scatter of the next); then compound 4; then compound 2.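

In this assay, the five-membered 1,3-thiazol-2-yl gives up some ground against the 4,6-dimethylpyrimidin-2-yl, with a 3.5-fold higher number from compound 3 to compound 4 (0.55 log units; beyond the scatter), yet still improves on the pyridin-2-yl, with a 3.7-fold lower number from compound 2 to compound 4 (0.56 log units; beyond the scatter). The three groups on the sulfonamide nitrogen thus give three separate levels, and since the six-membered groups of compound 2 and compound 3 fall on opposite sides of compound 4, ring size alone does not set the order here. Nothing available gives a reason for these differences.

The compounds shown leave open whether the two methyl groups account for the lead of compound 3, as a 1,3-thiazol-2-yl carrying methyl groups could show. They also leave open whether the sulfonamide nitrogen needs an aromatic ring at all, or whether a simple acetyl group or a short alkyl chain would serve there.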